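Bromo in place of acetyl on a shared urea core

This account rests on a few compounds, and the source may have more. Where it says the series, first, only, none or still open, it means among the compounds named here.

Compound 1 `CCOC(=O)c1cccc(NC(=O)N[C@@H](C)c2ccccc2)c1`: 96%
Compound 2 `COc1cccc(NC(=O)N[C@@H](C)c2ccccc2)c1`: 99%
Compound 3 `CC(=O)c1cccc(NC(=O)N[C@@H](C)c2ccccc2)c1`: 94%

Of the compounds shown here, three sharing one urea core have been measured in an ADME assay on the whole organism with Oryza sativa as the target, tested at 10 uM; a lower number here means a stronger effect, a higher number a weaker effect of the compound at the concentration tested. Compound 1 `CCOC(=O)c1cccc(NC(=O)N[C@@H](C)c2ccccc2)c1` gives 96%, compound 2 `COc1cccc(NC(=O)N[C@@H](C)c2ccccc2)c1` gives 99%, and compound 3 `CC(=O)c1cccc(NC(=O)N[C@@H](C)c2ccccc2)c1` gives 94%. Compound 3 sits within the scatter of both neighbours: a number 2 percentage points lower from compound 1 to compound 3 (within the scatter), and a number 5 percentage points lower from compound 2 to compound 3 (within the scatter). Likewise a number 3 percentage points higher from compound 1 to compound 2 (within the scatter).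

Compound 4 `C[C@H](NC(=O)Nc1cccc(Br)c1)c1ccccc1` differs from compound 3 by bromo in place of acetyl on an aromatic carbon. For the measured compounds named here, the steps that bear on this are the exchanges of the group on the same aromatic carbon among compounds 1, 2 and 3; each of them stayed within the scatter, so a change of the aromatic substituent has so far left the read-out in this assay essentially unmoved. On that basis compound 4 is expected to show a step of a number 1 percentage points higher from compound 3 to compound 4 (within the scatter), that is, no step beyond the scatter. Compound 4 is therefore estimated at 95%, with a range from 86% to 100%.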

Compound 4, a percentage reported as activity, at one concentration (the size of the read-out at that concentration, not a potency): 99%
Beside the measured number, compound 4's estimate is 4 percentage points below it, and the stated range covers the measured number.
By their numbers in this assay, from the lowest: compounds 3, 1, 2 and 4 (each within the scatter of the next).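

In this assay, bromo, a single heavy atom with no hydrogen-bond acceptor, replaces acetyl with its double bond and hydrogen-bond acceptor, and the result is a number 5 percentage points higher from compound 3 to compound 4 (within the scatter); even this exchange, which leaves no acceptor on the group, does not carry the read-out beyond the scatter. The exchanges for the other two groups agree, with no change at the digits printed from compound 2 to compound 4 (within the scatter) and a number 3 percentage points higher from compound 1 to compound 4 (within the scatter), so ethoxycarbonyl, methoxy, acetyl and bromo on this aromatic carbon cannot be told apart in this assay. The data offer no evidence that would account for this lack of separation.

On these data alone, whether an amine or a carboxylic acid on this aromatic carbon would move the read-out beyond the scatter remains open. So does whether a longer chain in place of the methyl on the shared core would have any such effect.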